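The source may hold more compounds than are shown below. What is called first, only, known or untested is meant among the compounds shown, and "the series" means these compounds.

Within the data shown here, compound 3 `O=C1/C(=C/c2cccc(C(F)(F)F)c2)CCC/C1=C\c1cccc(C(F)(F)F)c1` is one of three compounds measured in a physicochemical assay for solubility, in phosphate buffer, at pH 7.4; a higher number here means a more soluble compound, a lower number a less soluble compound. In this assay compound 3 gives only a limit, < 1000 nM. Compound 1 `N#CC1(c2ccccc2)C/C(=C\c2ccc(C(F)(F)F)cc2)C(=O)/C(=C/c2ccc(C(F)(F)F)cc2)C1` likewise gives a limit, < 1000 nM. Compound 2 `N#CC1(c2ccccc2)C/C(=C\c2ccccc2)C(=O)/C(=C/c2ccccc2)C1` also gives a limit, < 1000 nM. Among the measured compounds shown here, compound 3 thus stands at the limit of < 1000 nM in this assay, at which 3 of the 3 values shown sit, so no step between measured compounds can be sized from these numbers. Compound 4 `CC1C/C(=C\c2cccc(C(F)(F)F)c2)C(=O)/C(=C/c2cccc(C(F)(F)F)c2)C1` differs from compound 3 by methyl in place of hydrogen on a saturated ring carbon. With every value at the limit, no direction can be read in this assay, and the expected step is none beyond the scatter. Compound 4 is therefore estimated at 400 nM, between 80 nM and 1500 nM, an expected step that the limit leaves unreadable from compound 3 to compound 4, most likely reported again only as a limit.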

Compound 4, solubility: < 1000 nM
Compound 4 ended at the assay's limit; the forecaster's own chance of this, stated with the estimate: 85%; the middle value is on the limit's open side.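

No step from compound 3 to compound 4 can be read in this assay, since neither gives a number: the limit of < 1000 nM in this assay, at which 4 of the 4 values shown sit.

The compounds shown leave open how far each lies from that limit, and whether methyl in place of hydrogen on a saturated ring carbon shifts the value at all.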